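This account rests on a few compounds, and the source may have more. Where it says the series, first, only, none or still open, it means among the compounds named here.

Measured so far in an in vitro ADME assay on microsomes (Homo sapiens) for metabolic stability, read by LC-MS, with a stated time of 15 min; on this read-out higher numbers stand for a longer-lived compound and lower numbers for a shorter-lived compound:
- compound 1 `CN1CCN(c2ccc(NC(=O)Nc3ccc(-c4nc(N5C6CCC5COC6)nc(N5[C@H](CO)CC[C@@H]5CO)n4)cc3)cc2)CC1`: 0.0917 h
- compound 2 `CC(C)Nc1nc(-c2ccc(NC(=O)Nc3ccc(N4CCN(C)CC4)cc3)cc2)nc(N2C3CCC2COC3)n1`: > 0.5 h (a limit)
- compound 3 `CCN1CCN(c2ccc(NC(=O)Nc3ccc(-c4nc(C5CCOCC5)nc(N5C6CCC5COC6)n4)cc3)cc2)CC1`: > 0.5 h (a limit)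

Not yet measured: compound 4 `CN(C)C1CCN(C(=O)c2ccc(NC(=O)Nc3ccc(-c4nc(C5CCOCC5)nc(N5C6CCC5COC6)n4)cc3)cc2)CC1`.

Compound 3 has no number on this assay, only the limit > 0.5 h. That places it with compound 2 at the same limit: the limit of > 0.5 h in this assay, at which 2 of the 3 values shown sit. Compound 4 carries (4-(dimethylamino)piperidin-1-yl)carbonyl in place of 4-ethylpiperazin-1-yl on an aromatic carbon, para to a large group: (4-(dimethylamino)piperidin-1-yl)carbonyl in place of 4-ethylpiperazin-1-yl on an aromatic carbon. Going by the values given here, no measured step touches this place. The only one, an at least 5.4-fold higher number from compound 1 to compound 2 (0.73 log units; beyond the scatter), exchanges 2,5-bis(hydroxymethyl)pyrrolidin-1-yl for isopropylamino at another place, so it gives no size for this change. With nothing measured to set a direction, no shift beyond the scatter is expected, and the expected step is an at least 1.1-fold lower number from compound 3 to compound 4 (0.04 log units; that floor lies within the scatter). The estimate for compound 4 is 0.45 h. The expected range for compound 4 runs from 0.17 h to 0.9 h, and a further limit rather than a number would be no surprise.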

Compound 4, half-life: > 0.5 h
Compound 4: a limit, no number (the forecaster's own chance of this, stated with the estimate: 55%); middle value at least 1.1-fold (0.04 log units) away from the limit.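

Compound 3 and compound 4 each give only a limit, not a number, in this assay, so no step can be read between them: the limit of > 0.5 h in this assay, at which 3 of the 4 values shown sit.

The compounds shown leave open whether exchanging 4-ethylpiperazin-1-yl for (4-(dimethylamino)piperidin-1-yl)carbonyl changes the half-life at all, and in which direction.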